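Shifting an amino group within a weakly cytotoxic series

This account rests on a few compounds, and the source may have more. Where it says the series, first, only, none or still open, it means among the compounds named here.

Of the compounds shown here, three have so far been tested in a functional assay on U-937 cells (Homo sapiens) for cytotoxicity, read by MTT assay, with a stated time of 48 h; a lower number here means a stronger inhibitor, a higher number a weaker inhibitor.

Compound 1 `Fc1cccc(Nc2nc(-c3cccc(F)c3)nc3ccc(F)cc23)c1` gives 42300 nM.
Compound 2 `Oc1ccc(Nc2nc(-c3cccc(F)c3)nc3ccc(F)cc23)cc1` gives > 50000 nM, which is a limit of the assay and not a number.
Compound 3 `Nc1ccc(Nc2nc(-c3cccc(F)c3)nc3ccc(F)cc23)cc1` gives > 50000 nM, again a limit of the assay.

Compound 3 therefore stands at the edge of what this assay can report, and two of the three values sit at that same edge (the limit of > 50000 nM in this assay, at which 2 of the 3 values shown sit). The measured steps are small or unreadable: an at least 1.1-fold higher number from compound 1 to compound 3 (0.07 log units; that floor lies within the scatter), an at least 1.1-fold higher number from compound 1 to compound 2 (0.07 log units; that floor lies within the scatter), and a step that the two limits leave unreadable from compound 2 to compound 3. None of them shows a change beyond the scatter.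

Compound 4 `Nc1cccc(Nc2nc(-c3cccc(F)c3)nc3ccc(F)cc23)c1` differs from compound 3 only in where the amino group sits: 3-aminophenyl in place of 4-aminophenyl on a nitrogen on an aromatic ring. The steps seen so far, all between compounds that are weak or at the limit, give no reason to expect a move out of that range, so the step that the limit leaves unreadable from compound 3 to compound 4 is expected to be none beyond the scatter. Compound 4 is estimated at 60000 nM, within 25000 nM to 150000 nM, most likely reported again as a limit.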

Compound 4, half-maximal inhibitory concentration: > 50000 nM
Compound 4: a limit, no number (the forecaster's own chance of this, stated with the estimate: 70%); the middle value does not contradict the limit.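

Compound 4 shows that the 3-aminophenyl group, like the 4-aminophenyl group of compound 3, gives no readable potency in this assay, so this shift of the amino group brings no measurable gain. Amino in place of fluoro on the same ring gives an at least 1.1-fold higher number from compound 1 to compound 4 (0.07 log units; that floor lies within the scatter), so this swap shows no change beyond the scatter. The steps linking compound 4 to compound 2 and compound 3 cannot be read, because the values at both ends of each step are limits: the limit of > 50000 nM in this assay, at which 3 of the 4 values shown sit.

From the compounds shown here alone, what remains open is how weak these compounds really are, as a limit hides the true value. Going by these compounds, it is also open whether a dimethylamino group or a carboxylic acid in place of the amino group would give a value clear of the limit.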